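The source may hold more compounds than are shown below. What is called first, only, known or untested is meant among the compounds shown, and "the series" means these compounds.

Series in a functional assay on A549 cells (Homo sapiens) for antiproliferative activity, read by sulforhodamine B assay, with a stated time of 72 h; on this read-out higher numbers stand for weaker inhibition and lower numbers for stronger inhibition:
Compound 1 `Cc1ccc(S(=O)(=O)Nc2cc(SCCC(=O)N[C@@H](CC(C)C)B(O)O)c(O)c3ccccc23)cc1`: 8190 nM
Compound 2 `CC(C)C[C@H](NC(=O)CCSc1cc(NS(=O)(=O)c2ccc(Cl)cc2)c2ccccc2c1O)B(O)O`: 8100 nM
Compound 3 `CC(=O)Nc1ccc(S(=O)(=O)Nc2cc(SCCC(=O)N[C@@H](CC(C)C)B(O)O)c(O)c3ccccc23)cc1`: not yet measured

Among the measured compounds shown here, compound 2, at 8100 nM, cannot be told apart from compound 1, the only other measured compound, at 8190 nM. The next change is acetamido in place of chloro on an aromatic carbon, para to a large group, which also reads as 4-chlorophenyl to 4-acetamidophenyl: acetamido in place of chloro on an aromatic carbon.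

For the measured compounds named here, only one measured step touches this substituent: a 1.0-fold lower number from compound 1 to compound 2 (0.00 log units; within the scatter). That step lies within the scatter, so no response to this substituent has been seen so far in this assay. Going by the values given here, it is thin support, resting on a single pair, and no measured compound carries acetamido, so the range is kept wide.

Among the compounds with values here, with a 1.0-fold lower number from compound 1 to compound 2 (0.00 log units; within the scatter) as the sole guide, no shift beyond the scatter is expected, in either direction. The estimated change is a 1.1-fold higher number from compound 2 to compound 3 (0.05 log units; within the scatter), which is expected to stay within the scatter. Compound 3 is estimated at 9000 nM, with an expected range of 3500 nM to 22000 nM.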

Compound 3, half-maximal inhibitory concentration: 5920 nM
Compound 3: the middle estimate sits 1.5-fold (0.18 log units) above what was measured; the range from low to high includes it.
By their numbers in this assay, from the lowest: compounds 3, 2 and 1 (each within the scatter of the next).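

In this assay, acetamido on an aromatic carbon, para to a large group, gives a 1.4-fold lower number from compound 2 to compound 3 (0.14 log units; within the scatter) against chloro and a 1.4-fold lower number from compound 1 to compound 3 (0.14 log units; within the scatter) against methyl. Compounds 1 and 2 had shown only that chloro and methyl could not be told apart; compound 3 extends this to a group with more heavy atoms than chloro and with a hydrogen-bond donor and acceptor that chloro lacks, and still no step leaves the scatter, so the three substituents shown cannot be separated at this position. No measurement is available that would explain this flat response.

As far as these compounds go, whether an amine or a carboxylic acid at this position, or a longer chain in place of the acetyl part of acetamido, would give a step beyond the scatter remains open. The rest of the structure is the same in all three compounds, so they also leave open how this assay responds to a change anywhere else on the shared core.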